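This account rests on a few compounds, and the source may have more. Where it says the series, first, only, none or still open, it means among the compounds named here.

Of the compounds shown here, two built on the shared core have been measured in a functional assay on PC-3 cells (Homo sapiens) for cytotoxicity; a lower number here means a stronger inhibitor, a higher number a weaker inhibitor. Compound 1 `O=C(N/N=C\c1cn(Cc2ccc(Cl)cc2)c2ccc(Br)cc12)c1c[nH]c2ccccc12` gives 12400 nM in this assay. Compound 2 `COc1ccc(Cn2cc(/C=N\NC(=O)c3cn(C)c4ccccc34)c3ccc(F)cc32)cc1` gives 12800 nM in this assay, and the two numbers sit within the usual scatter of each other, so nothing separates compound 1 from compound 2 on these data. Compound 3 `O=C(N/N=C\c1cn(Cc2ccc(Cl)cc2)c2ccccc12)c1c[nH]c2ccccc12` has not yet been measured. It differs from compound 1 in one place: hydrogen in place of bromo on an aromatic carbon. Going by the values given here, no pair of measured compounds differing in a single place is available, so the size of such a change cannot be read from these data. Since only one heavy atom leaves, compound 3 is expected to stay near compound 1, with a step of a 1.2-fold higher number from compound 1 to compound 3 (0.08 log units; within the scatter) that may well fall within the scatter and could go in either direction. Compound 3 is estimated at 15000 nM in this assay, within a range from 6000 nM to 40000 nM.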

Compound 3, half-maximal inhibitory concentration: 16200 nM
The estimate for compound 3 lay 1.1-fold (0.03 log units) below the measured number, within the range that was stated.
By their numbers in this assay, from the lowest: compounds 1, 2 and 3 (each within the scatter of the next).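

Going by these compounds alone, with hydrogen in place of bromo on an aromatic carbon, this assay gives a 1.3-fold higher number from compound 1 to compound 3 (0.12 log units; within the scatter), the first comparison of compounds that differ in only one place. Compound 1 and compound 3 therefore cannot be told apart on these data, and the bromo at this position is not needed for activity at this level. No measurement is available that could explain this result.

The compounds shown leave open whether a different group at this position, such as an amine or a carboxylic acid, would separate itself from hydrogen and bromo. They also leave open whether changes elsewhere on the shared core would matter, as this is the only position with a single-place comparison.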